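The compounds below may be only part of what the source reports. "The series", "measured", "known", "first", "only" and "open" are said of these compounds alone.

Measured in a functional assay on K562 cells (Homo sapiens) for cytotoxicity, read by trypan blue exclusion, with a stated time of 96 h; a higher number here means a weaker inhibitor, a lower number a stronger inhibitor:
- Compound 1 `COc1cc(OC)c(/C=C/S(=O)(=O)Nc2ccc(OC)c(O)c2)c(OC)c1`: 15 nM
- Compound 2 `COC(=O)C(C)(C)Nc1cc(NS(=O)(=O)/C=C/c2c(OC)cc(OC)cc2OC)ccc1OC`: 300 nM

Compound 2 has the higher of the two numbers, which makes it the weaker inhibitor of the pair. Among the measured compounds shown here, the one measured step is a 20-fold higher number from compound 1 to compound 2 (1.30 log units; beyond the scatter), and it comes with (1-(methoxycarbonyl)-1-methylethyl)amino in place of hydroxy on an aromatic carbon.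

Compound 3 `COC(=O)C(Nc1cc(NS(=O)(=O)/C=C/c2c(OC)cc(OC)cc2OC)ccc1OC)c1ccc(Br)cc1` has not yet been measured. It carries (4-bromophenyl)(methoxycarbonyl)methyl in place of 1-(methoxycarbonyl)-1-methylethyl on a nitrogen on an aromatic ring.

The measured step bears on this change only indirectly. It replaced hydroxy with the whole amino group, whereas here the nitrogen stays and only the group on it changes. For the measured compounds named here, no measured pair shows this exact swap, so the data give no direction for it. The large step from compound 1 still warns that a sizeable shift is possible, so the range must stay wide. No step beyond the scatter is therefore expected in this assay, and the estimated step is no change at the digits printed from compound 2 to compound 3 (within the scatter). For compound 3 the expected value is 300 nM, with an estimated range of 60 nM to 1500 nM.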

Compound 3, half-maximal inhibitory concentration: 1000 nM
The estimate for compound 3 lay 3.3-fold (0.52 log units) below the measured number; the measured number falls inside the stated range.
By their numbers in this assay, from the lowest: compound 1; then compound 2; then compound 3.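

In this assay, the group carried on the nitrogen can move the number by itself: replacing 1-(methoxycarbonyl)-1-methylethyl with (4-bromophenyl)(methoxycarbonyl)methyl gives a 3.3-fold higher number from compound 2 to compound 3 (0.52 log units; beyond the scatter). The earlier step exchanged hydroxy for the whole amino group, so it could not separate the arrival of the nitrogen from the group attached to it, whereas this pair keeps the nitrogen and the methoxycarbonyl group in both compounds. The new group brings a six-membered aromatic ring and a bromine, and the step it produces is modest, but no measurement here shows what causes the shift.

From the compounds shown here alone, the aromatic ring and the bromine enter together in this one change, so their separate contributions remain unknown; a plain phenyl group or a 4-chlorophenyl group in the same place would be needed to tell them apart. The compounds shown also leave open how much the methoxycarbonyl group itself matters, a question that could be tested by putting a carboxylic acid or an amide in its place.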